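The compounds below may be only part of what the source reports. "The series", "measured", "known", "first", "only" and "open" are said of these compounds alone.

Measured so far in a functional assay on LNCaP cells (Homo sapiens) for antiproliferative activity, read by WST assay, with a stated time of 3 days; on this read-out lower numbers stand for stronger inhibition and higher numbers for weaker inhibition:
- compound 1 (`CCOc1c(-c2cc(OC)c(OC)c(OC)c2)oc2ccccc2c1=O`) gives 5400 nM
- compound 2 (`CCCCCOc1c(-c2cc(OC)c(OC)c(OC)c2)oc2ccccc2c1=O`) gives 15400 nM
- compound 3 (`CCN(CC)CCCCCOc1c(-c2cc(OC)c(OC)c(OC)c2)oc2ccccc2c1=O`) gives 10000 nM

Compound 3 (10000 nM) lies within the scatter of both compound 1 and compound 2. Compound 4 (`CCCCN(CCCC)CCCCOc1c(-c2cc(OC)c(OC)c(OC)c2)oc2ccccc2c1=O`) carries dibutylamino in place of (diethylamino)methyl on a saturated chain carbon, four bonds along the chain from an oxygen on an aromatic ring. Among the compounds with values here, three measured steps bear on this. Only propyl in place of hydrogen (a 2.9-fold higher number from compound 1 to compound 2 (0.46 log units; beyond the scatter)) goes beyond the scatter, and modestly. Diethylamino in place of hydrogen (a 1.5-fold lower number from compound 2 to compound 3 (0.19 log units; within the scatter)) and 3-(diethylamino)propyl in place of hydrogen (a 1.9-fold higher number from compound 1 to compound 3 (0.27 log units; within the scatter)) both stay within it. No step beyond the scatter is therefore expected in this assay for this change. The estimated step is small (a 1.4-fold lower number from compound 3 to compound 4 (0.15 log units; within the scatter)). Compound 4 is expected at 7000 nM within an estimated range (2500 nM to 16000 nM).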

Compound 4, half-maximal inhibitory concentration: 7800 nM
The estimate for compound 4 lay 1.1-fold (0.05 log units) below the measured number; measured number inside the range.
By their numbers in this assay, from the lowest: compounds 1, 4, 3 and 2 (each within the scatter of the next, the first and the last beyond it).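

In this assay, dibutylamino in place of (diethylamino)methyl, on a saturated chain carbon four bonds along the chain from an oxygen on an aromatic ring, stays within the scatter (a 1.3-fold lower number from compound 3 to compound 4 (0.11 log units; within the scatter)), although nine heavy atoms enter and six leave. The steps from the two compounds without an amine also stay within it (a 2.0-fold lower number from compound 2 to compound 4 (0.30 log units; within the scatter); a 1.4-fold higher number from compound 1 to compound 4 (0.16 log units; within the scatter)). Nothing available explains these numbers.

Going by these compounds, whether piperidine or a carboxylic acid in place of dibutylamino would give a step beyond the scatter remains open.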